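The source may report more compounds than this note shows. Statements on the series, on what has been measured and on what is new or still open speak of the compounds shown alone.

Measured so far:
compound 1, `CCOC(=O)CO/N=C(\C)c1ccc(Sc2cc(F)cc(C3CCOCC3)c2)cc1`, gives 610 nM
compound 2, `CS/C(=N\O)c1ccc(Sc2cc(F)cc(C3CCOCC3)c2)cc1`, gives 190 nM

Both numbers come from a functional assay (blood) for inhibition, with Homo sapiens as the target; a higher number here means a weaker inhibitor, a lower number a stronger inhibitor. Within the data shown here, compound 1 stands at the higher of the two; the only step known, a 3.2-fold lower number from compound 1 to compound 2 (0.51 log units; beyond the scatter), replaces the whole group hanging on the aromatic carbon of the shared core. Compound 3, `C/C(=N\OCCSc1nnc(C)s1)c1ccc(Sc2cc(F)cc(C3CCOCC3)c2)cc1`, has not been measured. It differs from compound 1 in one place: ((5-methyl-1,3,4-thiadiazol-2-yl)sulfanyl)methyl in place of ethoxycarbonyl on a saturated chain carbon bound to an oxygen on an unsaturated carbon. Among the measured compounds shown here, no measured step alters this part of the chain while keeping the rest of compound 1, so the step from compound 1 to compound 2 bears on it only loosely, as a sign that this region tolerates change without a large swing. A step within the scatter is therefore expected, with wide uncertainty. Compound 3 is estimated at 500 nM. For compound 3 the expected range runs from 150 nM to 2000 nM. The expected step is a 1.2-fold lower number from compound 1 to compound 3 (0.09 log units; within the scatter).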

Compound 3, half-maximal inhibitory concentration: 230 nM
For compound 3 the middle estimate is 2.2-fold (0.34 log units) above the measured one, within the range that was stated.
By their numbers in this assay, from the lowest: compounds 2 and 3 (each within the scatter of the next); then compound 1.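

Exchanging ethoxycarbonyl for ((5-methyl-1,3,4-thiadiazol-2-yl)sulfanyl)methyl on a saturated chain carbon bound to an oxygen on an unsaturated carbon gives, in this assay, a 2.7-fold lower number from compound 1 to compound 3 (0.42 log units; beyond the scatter). Among these compounds, this is the first direct reading of a change at this place on the chain: the ethoxycarbonyl group is not needed to keep inhibition, and a group carrying a five-membered aromatic ring gives the stronger inhibitor of this pair. No data at hand explain the gain.

The ring, the sulfanyl link and the change in chain all enter together in this one swap, so their separate shares cannot be told apart. On these data alone, how a simple methylsulfanyl group, an amine or a carboxylic acid would read at this place remains open.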